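The source may hold more compounds than are shown below. What is called first, only, known or untested is meant among the compounds shown, and "the series" means these compounds.

Of the compounds shown here, three built on one shared core have been tested in a functional assay on MGC-803 cells (Homo sapiens) for antiproliferative activity, read by MTT assay, with a stated time of 48 h; on this read-out higher numbers stand for weaker inhibition and lower numbers for stronger inhibition. Compound 1 `O=C(Nc1cccc(CNc2nccnc2Cl)c1)Nc1ccc(Cl)c(Cl)c1` gives 4970 nM; compound 2 `CN(C)c1ccc(NC(=O)Nc2cccc(CNc3nccnc3Cl)c2)cc1` gives 11500 nM; compound 3 `CCc1ccccc1NC(=O)Nc1cccc(CNc2nccnc2Cl)c1` gives 9370 nM. Compound 3 stands second highest of these three numbers, nearest to compound 2 and furthest from compound 1, and both steps, a 1.2-fold lower number from compound 2 to compound 3 (0.09 log units; within the scatter) and a 1.9-fold higher number from compound 1 to compound 3 (0.28 log units; within the scatter), lie within the scatter. Compound 4 `O=C(Nc1cccc(Cl)c1)Nc1cccc(CNc2nccnc2Cl)c1` differs from compound 3 by 3-chlorophenyl in place of 2-ethylphenyl on an amide-type nitrogen. Among the compounds with values here, the steps that bear on this are a 1.9-fold higher number from compound 1 to compound 3 (0.28 log units; within the scatter), within the scatter, and a 2.3-fold higher number from compound 1 to compound 2 (0.36 log units; beyond the scatter), modest; compound 1, carrying 3,4-dichlorophenyl, shows the lowest number so far. The change is therefore expected to give a 1.4-fold lower number from compound 3 to compound 4 (0.16 log units; within the scatter), a small move toward stronger inhibition or none beyond the scatter. Compound 4 is estimated at 6500 nM, within a range of 3000 nM to 14000 nM.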

Compound 4, half-maximal inhibitory concentration: 5330 nM
Compound 4: the middle estimate sits 1.2-fold (0.09 log units) above what was measured; the range from low to high includes it.
By their numbers in this assay, from the lowest: compounds 1, 4, 3 and 2 (each within the scatter of the next, the first and the last beyond it).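

Taking one chlorine off the ring gives a 1.1-fold higher number from compound 1 to compound 4 (0.03 log units; within the scatter) in this assay, so 3-chlorophenyl and 3,4-dichlorophenyl cannot be told apart here. Within the data shown here, replacing 2-ethylphenyl gives a 1.8-fold lower number from compound 3 to compound 4 (0.25 log units; within the scatter) and also separates nothing, whereas replacing 4-(dimethylamino)phenyl gives a 2.2-fold lower number from compound 2 to compound 4 (0.33 log units; beyond the scatter) as a modest move toward stronger inhibition, the only new step beyond the scatter. No measurement at hand explains these differences.
The compounds shown leave open how a methoxy group, a carboxylic acid or a longer chain on this ring would fare. They also leave open whether changes elsewhere in the shared core would move the numbers further than these ring swaps.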